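Dropping one methoxy group from compound 1

A few compounds are considered here, and "the series" means these few. Any claim that something is new, unique, unknown or untested is made for them only; others in the source may bear on it.

Compound 1 `COc1cc(O)c(C(=O)/C=C/c2cc(OC)c(OC)c(OC)c2)cc1OC`: > 25000 nM (a limit)
Compound 2 `COc1ccc(C(=O)/C=C/c2ccc(OC)c(OC)c2)c(O)c1`: > 100000 nM (a limit)

In an ADME assay on THP-1 cells (Homo sapiens) for cytotoxicity, read by MTT assay (on this read-out higher numbers stand for lower toxicity in this test and lower numbers for higher toxicity in this test), compound 1 gives > 25000 nM, which is a limit of the assay and not a number. Compound 2 gives > 100000 nM, which is also a limit. Compound 1 therefore has no exact position on the scale.

Compound 3 `COc1ccc(O)c(C(=O)/C=C/c2cc(OC)c(OC)c(OC)c2)c1` differs from compound 1 in one place: hydrogen in place of methoxy on an aromatic carbon. Hydrogen replaces methoxy on an aromatic carbon, ortho to a methoxy group, meta to a hydroxy group and para to a large group.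

Within the data shown here, no measured step between similar compounds is available, so no change beyond the usual scatter is expected in this assay, in either direction. The expected step is a step that the limit leaves unreadable from compound 1 to compound 3. For compound 3 the estimate is 40000 nM, with an expected range from 12000 nM to 100000 nM.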

Compound 3, half-maximal cytotoxic concentration in the THP-1 assay: > 25000 nM
Compound 3 gave a limit, no number; the forecaster's own chance of this, stated with the estimate: 70%; the middle value lies beyond the limit too.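

In the THP-1 assay compound 1 gives > 25000 nM as a limit of the assay and not a number. In the THP-1 assay compound 3 gives > 25000 nM as a limit of the assay too. Among these compounds, no step between them can be read, so whether hydrogen in place of methoxy shifts the toxicity in this test at all stays open. In a physicochemical assay for lipophilicity (on this read-out higher numbers stand for higher lipophilicity and lower numbers for lower lipophilicity), compound 1 gives 3.5 and compound 3 gives 3.47 and these two values lie within the scatter of each other.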